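A few compounds are considered here, and "the series" means these few. Any claim that something is new, unique, unknown or untested is made for them only; others in the source may bear on it.

Compound 1 `O=C(NOCc1ccccc1)c1cn(-c2ccccc2)nc1-c1ccccc1`: 13400 nM
Compound 2 `O=C(NOCc1ccccc1F)c1cn(-c2ccccc2)nc1-c1ccccc1`: 16100 nM
Compound 3 `COc1ccc(-c2nn(-c3ccccc3)cc2C(=O)NOCc2ccccc2)cc1`: 2770 nM

These three compounds share one core and were tested in a functional assay on MCF7 cells (Homo sapiens) for antiproliferative activity, read by MTT assay, with a stated time of 48 h, in the presence of a further agent that is not named here; on this read-out lower numbers stand for stronger inhibition of growth and higher numbers for weaker inhibition of growth. Compound 2 differs from compound 1 by fluoro in place of hydrogen on an aromatic carbon, and this change gave a 1.2-fold higher number from compound 1 to compound 2 (0.08 log units; within the scatter). Compound 3 differs from compound 1 by methoxy in place of hydrogen on an aromatic carbon, and this change gave a 4.8-fold lower number from compound 1 to compound 3 (0.68 log units; beyond the scatter), the only clear shift among the three.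

Compound 4 `COc1ccc(-c2nn(-c3ccccc3)cc2C(=O)NOCc2ccccc2F)cc1` has not yet been measured. It differs from compound 3 by fluoro in place of hydrogen on an aromatic carbon, which is the same change as that from compound 1 to compound 2, now made on the core of compound 3. Because the measured step was a 1.2-fold higher number from compound 1 to compound 2 (0.08 log units; within the scatter), the step from compound 3 to compound 4 is expected to be of similar size, a 1.2-fold higher number from compound 3 to compound 4 (0.06 log units; within the scatter). For compound 4 a value of about 3200 nM is therefore estimated.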

Compound 4, concentration for 50% growth inhibition: 6000 nM
The estimate for compound 4 lay 1.9-fold (0.27 log units) below the measured number; the range from low to high includes it.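

In this assay, fluoro in place of hydrogen gave a 2.2-fold higher number from compound 3 to compound 4 (0.34 log units; beyond the scatter), and methoxy in place of hydrogen gave a 2.7-fold lower number from compound 2 to compound 4 (0.43 log units; beyond the scatter). The fluoro change carried from one core to the other with no clear difference in the size of its effect: the same change on two cores in this assay, a 1.2-fold higher number (0.08 log units; within the scatter) from compound 1 to compound 2 and a 2.2-fold higher number (0.34 log units; beyond the scatter) from compound 3 to compound 4, 1.8-fold (0.26 log units) apart, within the scatter of two such steps. The methoxy change carried over in the same way, though a single pair of cores for each change does not show that either would hold on any other core: the same change on two cores in this assay, a 4.8-fold lower number (0.68 log units; beyond the scatter) from compound 1 to compound 3 and a 2.7-fold lower number (0.43 log units; beyond the scatter) from compound 2 to compound 4, 1.8-fold (0.26 log units) apart, within the scatter of two such steps.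

The compounds shown leave open whether an amine or a carboxylic acid in place of the methoxy group would lower the number as well. They also leave open how a longer chain in place of the benzyl group would behave.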